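A few compounds are considered here, and "the series" means these few. Any claim that something is new, unique, unknown or untested is made for them only; others in the source may bear on it.

Measured in a functional assay on SGC-7901 cells (Homo sapiens) for inhibition, read by MTT assay, with a stated time of 24 h (on this read-out lower numbers stand for stronger inhibition and higher numbers for weaker inhibition), so far:
- compound 1 `CC1(C)[C@H]2CC[C@]1(C)N(Cc1cn(-c3ccccc3C#N)nn1)C(=O)C2` gives 260 nM
- compound 2 `CC1(C)[C@H]2CC[C@]1(C)N(Cc1cn(-c3ccccc3O)nn1)C(=O)C2` gives 410 nM
- compound 3 `COc1cccc(-n2cc(CN3C(=O)C[C@@H]4CC[C@@]3(C)C4(C)C)nn2)c1` gives 590 nM

Compound 3 cannot be told apart from compound 2 (a 1.4-fold higher number from compound 2 to compound 3 (0.16 log units; within the scatter)), while its number is higher than that of compound 1 (a 2.3-fold higher number from compound 1 to compound 3 (0.36 log units; beyond the scatter)). The next compound, compound 4 `Cc1cccc(-n2cc(CN3C(=O)C[C@@H]4CC[C@@]3(C)C4(C)C)nn2)c1`, has methyl in place of methoxy on an aromatic carbon, meta to a large group (methyl in place of methoxy on an aromatic carbon).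

Going by the values given here, no measured pair makes this exact swap. The closest evidence comes from the two steps above, which replace the whole aromatic group on an aromatic nitrogen. One stays within the scatter and the other goes modestly beyond it. Among the compounds with values here, the new change alters only a single group on that aromatic ring, so no step beyond the scatter is expected in this assay, and no direction can be favoured. The expected step is small (a 1.1-fold lower number from compound 3 to compound 4 (0.05 log units; within the scatter)). The estimate for compound 4 is 520 nM, with an expected range from 240 nM to 1100 nM as the likely span.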

Compound 4, half-maximal inhibitory concentration: 410 nM
Compound 4: the middle estimate sits 1.3-fold (0.10 log units) above what was measured; the range from low to high includes it.
By their numbers in this assay, from the lowest: compounds 1, 2, 4 and 3 (each within the scatter of the next, the first and the last beyond it).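

Replacing methoxy with methyl at this ring position removes a hydrogen-bond acceptor and a heavy atom, yet the change stays within the scatter (a 1.4-fold lower number from compound 3 to compound 4 (0.16 log units; within the scatter)). The 3-methylphenyl group of compound 4 also cannot be told apart from the 2-hydroxyphenyl group (no change at the digits printed from compound 2 to compound 4 (within the scatter)) or the 2-cyanophenyl group (a 1.6-fold higher number from compound 1 to compound 4 (0.20 log units; within the scatter)), whereas the 3-methoxyphenyl group does stand apart from the latter, though only modestly (a 2.3-fold higher number from compound 1 to compound 3 (0.36 log units; beyond the scatter)). Nothing available explains why these numbers fall as they do.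

Still open, as far as these compounds go, is whether an amine or a carboxylic acid on this aromatic carbon would shift the number beyond the scatter. A longer chain, such as butoxy, poses the same question, as do changes to the shared core.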